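Solubility notes: cyclopropyl to cyclobutyl amide in the quinazoline series

The source may report more compounds than this note shows. Statements on the series, on what has been measured and on what is new or still open speak of the compounds shown alone.

Two compounds of the series carry numbers in a physicochemical assay for solubility, in phosphate buffer; on this read-out lower numbers stand for lower solubility and higher numbers for higher solubility. Compound 1 `Cc1nc(N2CCC(N3CCCC3)CC2)nc2ccc(NC(=O)C(C)Oc3ccc(Cl)cc3)cc12` gives 272000 nM in this assay. Compound 2 `Cc1nc(N2CCN(C(=O)C3CC3)CC2)nc2ccc(NC(=O)COc3ccc(OC(F)(F)F)cc3)cc12` gives 8000 nM in this assay, the lower of the two numbers; the gap from compound 1 to compound 2 lies beyond the usual scatter. For the measured compounds named here, the two compounds differ in several places at once, so no single step between them is defined, and only the two values themselves are recorded.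

Compound 3 `Cc1nc(N2CCN(C(=O)C3CCC3)CC2)nc2ccc(NC(=O)COc3ccc(OC(F)(F)F)cc3)cc12` has not yet been measured in this assay. It differs from compound 2 in one place: cyclobutyl in place of cyclopropyl on a carbonyl carbon. Both rings are carbon only, with no hydrogen-bond donors or acceptors on either side of the change, and the amide-type nitrogen in the ring that holds the carbonyl is unchanged.

Going by the values given here, no measured pair of this kind exists to set the size of such a step. The expectation is a step from compound 2 to compound 3 of a 1.3-fold lower number from compound 2 to compound 3 (0.12 log units; within the scatter) in this assay, slightly downward but not beyond the scatter. On that basis compound 3 is estimated at 6000 nM in this assay, with a range from 2500 nM to 15000 nM.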

Compound 3, solubility: 4000 nM
Beside the measured number, compound 3's estimate is 1.5-fold (0.18 log units) above it; low and high end bracket the measured number.
By their numbers in this assay, from the lowest: compounds 3 and 2 (each within the scatter of the next); then compound 1.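

For the compounds shown here, with this pair the series has its first step at a single place: cyclobutyl in place of cyclopropyl on a carbonyl carbon gives a 2.0-fold lower number from compound 2 to compound 3 (0.30 log units; within the scatter) in this assay, whereas compound 1 and compound 2 differ in several places at once and define no step. On this one pair, then, going from the three-membered to the four-membered carbon-only ring, with the amide-type nitrogen in a ring unchanged and no hydrogen-bond donors or acceptors on either side, does not separate compound 2 and compound 3 on this read-out beyond the usual scatter. No measurement in hand bears on why the two compounds read as they do.

Going by these compounds alone, the position has so far been seen only with these two small carbon-only rings, so the read-out for a carbonyl carbon carrying an amine, a carboxylic acid or a longer chain remains open. A single pair also leaves open whether the same exchange of cyclopropyl for cyclobutyl would stay within the scatter on other compounds of the series, where the rest of the structure differs.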